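Swapping chloro for trifluoromethyl on compound 2

The source may report more compounds than this note shows. Statements on the series, on what has been measured and on what is new or still open speak of the compounds shown alone.

Measured so far in an ADME assay on L6 cells (Rattus norvegicus) for cytotoxicity (on this read-out higher numbers stand for weaker inhibition and lower numbers for stronger inhibition), are two compounds
compound 1 `COc1ccc(N2CCN(C(=O)Cn3cnc([N+](=O)[O-])n3)CC2)cc1` gives 133000 nM
compound 2 `O=C(Cn1cnc([N+](=O)[O-])n1)N1CCN(c2ccc(Cl)cc2)CC1` gives > 285000 nM

For compound 2 the reading of > 285000 nM is a limit and not a number. Compound 3 `O=C(Cn1cnc([N+](=O)[O-])n1)N1CCN(c2ccc(C(F)(F)F)cc2)CC1` differs from compound 2 by trifluoromethyl in place of chloro on an aromatic carbon in that trifluoromethyl replaces chloro on an aromatic carbon. For the measured compounds named here, the only measured step at that carbon, chloro in place of methoxy, is an at least 2.1-fold higher number from compound 1 to compound 2 (0.33 log units; beyond the scatter) and gives only indirect guidance. In this assay the expected change is an at least 1.2-fold lower number from compound 2 to compound 3 (0.09 log units; that floor lies within the scatter) with no step beyond the scatter anticipated. Compound 3 is expected near 230000 nM within an estimated range of 90000 nM to 400000 nM in this assay.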

Compound 3, half-maximal inhibitory concentration: 202000 nM
Estimate against measurement, compound 3: 1.1-fold (0.06 log units) above, and the stated range covers the measured number.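

In this assay, trifluoromethyl in place of methoxy on this aromatic carbon gives a 1.5-fold higher number from compound 1 to compound 3 (0.18 log units; within the scatter), so these two groups cannot be told apart here, unlike chloro and methoxy in the earlier step. Trifluoromethyl in place of chloro gives an at least 1.4-fold lower number from compound 2 to compound 3 (0.14 log units; that floor lies within the scatter), which is a floor and shows no change beyond the scatter. The true size of that step stays unknown because compound 2 has a limit and not a number: the limit of > 285000 nM in this assay, at which 1 of the 3 values shown sits.

From the compounds shown here alone, whether an amine or a carboxylic acid on this carbon would shift the number beyond the scatter remains open.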